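This account rests on a few compounds, and the source may have more. Where it says the series, first, only, none or still open, it means among the compounds named here.

Measured so far in a functional assay on A549 cells (Homo sapiens) for antiproliferative activity, read by sulforhodamine B assay, with a stated time of 72 h (on this read-out higher numbers stand for weaker inhibition and lower numbers for stronger inhibition), are two compounds:
Compound 1 `Cc1ccc(S(=O)(=O)Nc2cc(SC(C)C(=O)N[C@@H](CC(C)C)B(O)O)c(O)c3ccccc23)cc1` gives 7280 nM
Compound 2 `CC(C)C[C@H](NC(=O)C(C)Sc1cc(NS(=O)(=O)c2ccccc2)c2ccccc2c1O)B(O)O` gives 4560 nM; 4480 nM (2 entries)

Among the measured compounds shown here, compound 1 has 7280 nM as its only single number in this assay and has one further entry without a single number. Compound 2 at 4560 nM; 4480 nM (2 entries) lies within the usual scatter of that value, so these two compounds cannot be ranked.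

Compound 3 `CC(=O)Nc1ccc(S(=O)(=O)Nc2cc(SC(C)C(=O)N[C@@H](CC(C)C)B(O)O)c(O)c3ccccc23)cc1` keeps the core of compound 1 and changes one group, 4-methylphenyl to 4-acetamidophenyl. This places acetamido in place of methyl on an aromatic carbon, para to a large group (acetamido in place of methyl on an aromatic carbon).

For the measured compounds named here, no measured pair here shows what such a change does, so the data favour no direction. The expected step (a 1.3-fold lower number from compound 1 to compound 3 (0.12 log units; within the scatter)) is therefore none beyond the usual scatter. This expectation leans only on the level set by compound 1 at 7280 nM and compound 2 at 4560 nM; 4480 nM (2 entries) as the two available anchors. Compound 3 is estimated at 5500 nM with an expected range from 1800 nM to 15000 nM in this read-out.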

Compound 3, half-maximal inhibitory concentration: 6370 nM
The estimate for compound 3 lay 1.2-fold (0.06 log units) below the measured number, within the range that was stated.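

In this assay, replacing methyl with acetamido on this aromatic carbon, para to a large group, gives a 1.1-fold lower number from compound 1 to compound 3 (0.06 log units; within the scatter). Among the compounds shown here, compounds 1 and 2 offered no measured step for this change, whereas this pair shows that the position accepts the larger acetamido group, with its hydrogen-bond donor and hydrogen-bond acceptor, without a difference that can be read beyond the usual scatter. How closely repeated readings of one compound can agree in this assay is shown by: the several entries of compound 2 in this assay, 4560 nM; 4480 nM (2 entries)

As far as these compounds go, whether a different group at this place, such as an amine, a carboxylic acid or a longer chain, would move the number beyond the scatter remains open. A single pair also cannot show whether the change from 4-methylphenyl to 4-acetamidophenyl would give a similar result on a different core, or whether other parts of the shared core matter more for the activity in these cells.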